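The compounds below may be only part of what the source reports. "The series", "measured", "known", "first", "only" and "open" are said of these compounds alone.

Working notes on the series.

Three compounds share one core. Compound 1 `COc1cc(Cl)cc(-c2nn(-c3cccc(NC(=O)c4ccc(Cl)c(Cl)c4)c3)cc2-c2ccncc2)c1` carries a 3,4-dichlorophenyl on a carbonyl carbon; in a functional assay on IGROV-1 cells (Homo sapiens) for inhibition, read by sulforhodamine B assay, with a stated time of 48 h, tested at 10 uM (a lower number here means a stronger effect, a higher number a weaker effect of the compound at the concentration tested), compound 1 gives 71.6%. Compound 3 `COc1cc(Cl)cc(-c2nn(-c3cccc(NC(=O)Nc4ccc(Cl)c(Cl)c4)c3)cc2-c2ccncc2)c1` carries (3,4-dichlorophenyl)amino at that carbon instead, and in this assay compound 3 gives 36.7%. Compound 2 `COc1cc(Cl)cc(-c2nn(-c3cccc(NC(=O)Nc4cc(C(F)(F)F)cc(C(F)(F)F)c4)c3)cc2-c2ccncc2)c1` has a bis(trifluoromethyl)phenyl group on the urea nitrogen, and in this assay compound 2 gives 23%. Among the compounds with values here, compound 3 therefore stands second among the three numbers: the only single-point step so far, a number 34.9 percentage points lower from compound 1 to compound 3 (beyond the scatter), is large, and the number for compound 2 is lower still, beyond the scatter.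

Compound 4 `COc1cc(Cl)cc(-c2nn(-c3cccc(NC(=O)Nc4cccc(C(F)(F)F)c4)c3)cc2-c2ccncc2)c1` is next: 3-(trifluoromethyl)phenyl in place of 3,4-dichlorophenyl on an amide-type nitrogen. Within the data shown here, no measured step covers an exchange of this kind on the amide-type nitrogen; the one step known changes the link to the carbonyl, not the aryl group. The values of compound 2 and compound 3 show that two different aryl groups on the urea nitrogen both sit well below compound 1, and a third is expected to fall in the same region. The step of a number 3.7 percentage points lower from compound 3 to compound 4 (within the scatter) is estimated to lie within the scatter. For compound 4 a value of 33% is expected, in the range 18% to 50%.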

Compound 4, a percentage reported as activity, at one concentration (the size of the read-out at that concentration, not a potency): 28.9%
Compound 4: middle estimate off by 4.1 percentage points, on the high side; the range from low to high includes it.
By their numbers in this assay, from the lowest: compounds 2, 4 and 3 (each within the scatter of the next, the first and the last beyond it); then compound 1.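

In this assay, the aryl exchange on the amide-type nitrogen gives a number 7.8 percentage points lower from compound 3 to compound 4 (within the scatter), and hydrogen in place of trifluoromethyl on an aromatic carbon gives a number 5.9 percentage points higher from compound 2 to compound 4 (within the scatter), so neither change is resolved at this position. The much larger change on the carbonyl carbon, with (3-(trifluoromethyl)phenyl)amino in place of 3,4-dichlorophenyl, gives a number 42.7 percentage points lower from compound 1 to compound 4 (beyond the scatter), a second large step of this kind alongside a number 34.9 percentage points lower from compound 1 to compound 3 (beyond the scatter). No available evidence bears on why these aryl exchanges stay within the scatter while the changes on the carbonyl carbon do not.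

The compounds shown leave open whether the same holds when the group on the amide-type nitrogen carries an amine or a carboxylic acid on its ring, or when a longer chain replaces the aryl group. They also leave open whether a stronger or weaker effect at this single concentration would hold at other concentrations.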